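A tert-butyl group added to compound 3

The source may hold more compounds than are shown below. What is called first, only, known or untested is meant among the compounds shown, and "the series" means these compounds.

In a functional assay on MCF7 cells (Homo sapiens) for inhibition, read by CCK-8 assay, with a stated time of 72 h (on this read-out higher numbers stand for weaker inhibition and lower numbers for stronger inhibition), three compounds have been measured so far: compound 1 (`O=C(/C=C/c1cccnc1)NCCCCCCCc1ccc(S(=O)(=O)Nc2ccccc2)cc1`) gives (37.6 nM), compound 2 (`O=C(/C=C/c1cccnc1)NCCCCCc1cccc(S(=O)(=O)Nc2ccccc2)c1`) gives (12.5 nM) and compound 3 (`O=C(/C=C/c1cccnc1)NCCCCCCc1cccc(S(=O)(=O)Nc2ccccc2)c1`) gives (0.63 nM). Compound 3 holds the lowest number of the three, and its gap to each of the others lies beyond the scatter. The next compound, compound 4 (`CC(C)(C)c1ccc(NS(=O)(=O)c2cccc(CCCCCCNC(=O)/C=C/c3cccnc3)c2)cc1`), keeps all of compound 3 except that phenyl becomes 4-(tert-butyl)phenyl (tert-butyl in place of hydrogen on an aromatic carbon), with tert-butyl in place of hydrogen on an aromatic carbon, para to a large group. For the measured compounds named here, no measured pair shows what such a change does, so the expectation is a loose one. With compound 3 at (0.63 nM), a moderate rise in the number, meaning weaker inhibition, is expected in this assay, although a step within the scatter would be no surprise. The expected step is a modest one (a 4.0-fold higher number from compound 3 to compound 4 (0.60 log units; beyond the scatter)). For compound 4 the estimated value is (2.5 nM), with an expected range from (0.4 nM) to (15 nM).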

Compound 4, half-maximal inhibitory concentration: 26.3 nM
For compound 4 the middle estimate is 11-fold (1.02 log units) below the measured one; the whole stated range lies below it.
By their numbers in this assay, from the lowest: compound 3; then compound 2; then compounds 4 and 1 (each within the scatter of the next).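

For the compounds shown here, until this result, the phenyl group of compound 3 was the same in every compound, so nothing showed how that ring responds to substitution. In this assay tert-butyl in place of hydrogen on an aromatic carbon, para to a large group, brings a 42-fold higher number from compound 3 to compound 4 (1.62 log units; beyond the scatter) and so shows that this carbon of the ring is far from indifferent to what it carries. The data offer no explanation for this rise.

From the compounds shown here alone, whether a methyl group or a fluorine atom on the same carbon would cost as much remains open, so it is unclear how much of the tert-butyl group is needed for the rise to appear. Equally open, going by these compounds, is how a methoxy group or a chlorine atom would read there.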